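From 3-methoxybenzyl to 2-methoxybenzyl: compound 3 to compound 4

A few compounds are considered here, and "the series" means these few. Any claim that something is new, unique, unknown or untested is made for them only; others in the source may bear on it.

compound 1 `O=C(O)C[C@H](O)C[C@H](O)CCn1c(-c2ccc(F)cc2)nc(C(=O)NCc2cccc(F)c2)c1C1CC1`: 0.1 nM
compound 2 `COc1ccc(CNC(=O)c2nc(-c3ccc(F)cc3)n(CC[C@@H](O)C[C@@H](O)CC(=O)O)c2C2CC2)cc1`: 0.2 nM
compound 3 `COc1cccc(CNC(=O)c2nc(-c3ccc(F)cc3)n(CC[C@@H](O)C[C@@H](O)CC(=O)O)c2C2CC2)c1`: 0.2 nM

All three values come from a functional assay on cells (Hepatocyte, Rattus norvegicus) for inhibition, read by scintillation counting, with a stated time of 4 h; on this read-out lower numbers stand for stronger inhibition and higher numbers for weaker inhibition. Compound 3 stands level with compound 2 at the digits given, the record showing no change at the digits printed from compound 2 to compound 3 (within the scatter). Its gap to the remaining compound is also small, with a 2.0-fold higher number from compound 1 to compound 3 (0.30 log units; within the scatter). The three compounds therefore cannot be ranked on these numbers.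

The next compound, compound 4 `COc1ccccc1CNC(=O)c1nc(-c2ccc(F)cc2)n(CC[C@@H](O)C[C@@H](O)CC(=O)O)c1C1CC1`, keeps everything else and differs by one change: 2-methoxyphenyl in place of 3-methoxyphenyl on a saturated chain carbon bound to an amide-type nitrogen. In words, 2-methoxyphenyl takes the place of 3-methoxyphenyl on a saturated chain carbon bound to an amide-type nitrogen.

For the measured compounds named here, the closest precedent is the exchange of 4-methoxyphenyl for 3-methoxyphenyl, which gave no change at the digits printed from compound 2 to compound 3 (within the scatter). The other measured steps on this group are also modest, among them a 2.0-fold higher number from compound 1 to compound 2 (0.30 log units; within the scatter). Going by the values given here, no measured compound carries the 2-methoxyphenyl group, so this precedent is indirect. In this assay, no shift beyond the scatter is therefore expected. The expected step is a 1.5-fold higher number from compound 3 to compound 4 (0.18 log units; within the scatter). For compound 4 the estimated value is 0.3 nM, with an expected range from 0.1 nM to 1 nM.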

Compound 4, half-maximal inhibitory concentration: 0.1 nM
Beside the measured number, compound 4's estimate is 3.0-fold (0.48 log units) above it; the measured number falls inside the stated range.
By their numbers in this assay, from the lowest: compounds 1, 4, 2 and 3 (each within the scatter of the next).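

With compound 4 the 2-methoxyphenyl, 3-methoxyphenyl and 4-methoxyphenyl groups can all be read at this place in this assay, and the placement of the methoxy group makes no difference beyond the scatter: the record shows a 2.0-fold lower number from compound 3 to compound 4 (0.30 log units; within the scatter) and a 2.0-fold lower number from compound 2 to compound 4 (0.30 log units; within the scatter). The earlier compounds shown here compared only the 3-methoxyphenyl and 4-methoxyphenyl groups, so this tolerance now extends to a third arrangement of the same atoms. The 2-methoxyphenyl group also cannot be told apart from the 3-fluorophenyl group of the first compound, with no change at the digits printed from compound 1 to compound 4 (within the scatter), so all four compounds remain unranked on these numbers. Nothing available explains why these values lie so close together.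

The compounds shown leave open whether this flat response holds for a different kind of group on the aromatic ring, such as a carboxylic acid or a dimethylamino group, or for an unsubstituted benzyl group. They also leave open whether it survives a longer chain between the amide nitrogen and the aromatic ring, for example a 2-phenylethyl group in place of the methoxybenzyl groups.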